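The compounds below may be only part of what the source reports. "The series", "measured", "known", "first", "only" and "open" are said of these compounds alone.

Measured in a toxicity assay on cells (Fibroblast, Homo sapiens) for cytotoxicity; on this read-out lower numbers stand for stronger inhibition and higher numbers for weaker inhibition:
Compound 1 `CC(/C=C/C1=CCCCC1(C)C)=C\C=C\C(C)=C\COC(=O)c1cc(O)c(O)c(O)c1`: 35000 nM
Compound 2 `CC(/C=C/C1=CCCCC1(C)C)=C\C=C\C(C)=C\COC(=O)c1cc(O)ccc1O`: 14000 nM
Compound 3 `CC(/C=C/C1=CCCCC1(C)C)=C\C=C\C(C)=C\COC(=O)c1c(O)cccc1O`: 14000 nM

Compound 3 sits at the low end of these numbers, level with compound 2, as no change at the digits printed from compound 2 to compound 3 (within the scatter) shows. The gap on the other side is a 2.5-fold lower number from compound 1 to compound 3 (0.40 log units; beyond the scatter).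

Compound 4 `COc1cccc(C(=O)OC/C=C(C)/C=C/C=C(C)/C=C/C2=CCCCC2(C)C)c1O` keeps the shared core but carries 2-hydroxy-3-methoxyphenyl in place of 2,6-dihydroxyphenyl on a carbonyl carbon. Within the data shown here, no measured compound carries a methoxy group, so the evidence is indirect. Exchanging one dihydroxyphenyl pattern for another gave no change at the digits printed from compound 2 to compound 3 (within the scatter), while the larger measured changes gave only a 2.5-fold lower number from compound 1 to compound 2 (0.40 log units; beyond the scatter). The expected outcome is therefore no step beyond the scatter, a 1.1-fold higher number from compound 3 to compound 4 (0.03 log units; within the scatter). For compound 4 the estimated value is 15000 nM, with an expected range of 7000 nM to 32000 nM.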

Compound 4, half-maximal inhibitory concentration: 27000 nM
Compound 4: middle estimate off by 1.8-fold (0.26 log units), on the low side; low and high end bracket the measured number.
By their numbers in this assay, from the lowest: compounds 2, 3, 4 and 1 (each within the scatter of the next, the first and the last beyond it).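

In this assay the only ring here that carries a methoxy group, 2-hydroxy-3-methoxyphenyl, stays within the scatter of all three other compounds, with a 1.9-fold higher number from compound 3 to compound 4 (0.29 log units; within the scatter) and a 1.9-fold higher number from compound 2 to compound 4 (0.29 log units; within the scatter) and also a 1.3-fold lower number from compound 1 to compound 4 (0.11 log units; within the scatter) as the steps. Compound 4 therefore cannot be ranked against any of them, even though compound 1 lies beyond the scatter of compound 2 and compound 3. Nothing measured here gives a reason for this. Still open, from the compounds shown here alone, is how the number responds at this place to a ring carrying an amine or a carboxylic acid.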